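Tertiary amide in place of benzylamide: compound 4

A few compounds are considered here, and "the series" means these few. Any claim that something is new, unique, unknown or untested is made for them only; others in the source may bear on it.

For the measured compounds named here, compound 1 `Cc1ccc(CNC(=O)c2[nH]cnc2C(=O)Nc2ccc(Cl)c(Cl)c2)cc1` gives 21400 nM in a functional assay on HL-60 cells (Homo sapiens), with a stated time of 2 days (on this read-out lower numbers stand for stronger inhibition and higher numbers for weaker inhibition), the second highest of the three numbers measured so far. Compound 2 `COc1ccc(CNC(=O)c2[nH]cnc2C(=O)Nc2ccc(Cl)c(Cl)c2)cc1` gives 24300 nM, and the step of a 1.1-fold higher number from compound 1 to compound 2 (0.06 log units; within the scatter) lies within the scatter. Compound 3 `C[C@H](NC(=O)c1[nH]cnc1C(=O)Nc1ccc(Cl)c(Cl)c1)C(=O)OC(C)(C)C` gives 4900 nM; the steps of a 4.4-fold lower number from compound 1 to compound 3 (0.64 log units; beyond the scatter) and a 5.0-fold lower number from compound 2 to compound 3 (0.70 log units; beyond the scatter) are both beyond the scatter and modest.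

Compound 4 `CCCN(CCC)C(=O)c1[nH]cnc1C(=O)Nc1ccc(Cl)c(Cl)c1` differs from compound 1 in one place: dipropylamino in place of (4-methylbenzyl)amino on a carbonyl carbon. Going by the values given here, the only measured steps touching this amide are those to compound 3, in which the aromatic ring is also removed but a hydrogen-bond donor remains on the nitrogen; compound 4 keeps no donor there, and no measured pair tests that. The modest lowering in a 4.4-fold lower number from compound 1 to compound 3 (0.64 log units; beyond the scatter) therefore bears on compound 4 only loosely. The expectation is a step from compound 1 to compound 4 of a 1.2-fold lower number from compound 1 to compound 4 (0.08 log units; within the scatter), that is, nothing clearly beyond the scatter. Compound 4 is expected to give about 18000 nM in this assay, with a range of 6000 nM to 55000 nM.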

Compound 4, half-maximal inhibitory concentration: 379000 nM
The estimate for compound 4 lay 21-fold (1.32 log units) below the measured number; the whole stated range lies below it.
By their numbers in this assay, from the lowest: compound 3; then compounds 1 and 2 (each within the scatter of the next); then compound 4.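

In this assay, for the compounds shown here, the nitrogen substituent on this carbonyl carbon proves far from indifferent: dipropylamino in place of (4-methylbenzyl)amino gives an 18-fold higher number from compound 1 to compound 4 (1.25 log units; beyond the scatter), a large step in the weakening direction, whereas the earlier steps at this amide were within the scatter or lowered the number. The change removes both the six-membered aromatic ring and the hydrogen-bond donor on the nitrogen, and this single step cannot separate the two. No measurement available here accounts for the size of the step.

Open, as far as these compounds go, is how propylamino, which keeps the amide hydrogen without the ring, would compare with N-methyl-(4-methylbenzyl)amino, which keeps the ring without the amide hydrogen. Either group would help show which of the two removals tracks with the higher number.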